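Phenyl versus benzofuranyl on two nucleoside cores

A few compounds are considered here, and "the series" means these few. Any claim that something is new, unique, unknown or untested is made for them only; others in the source may bear on it.

Compound 1 `Cc1nc(N)c2c(-c3ccccc3)cn([C@@H]3O[C@H](CO)[C@@H](O)[C@H]3O)c2n1`: > 100000 nM in an ADME assay on BJ cells (Homo sapiens), read by MTT assay, with a stated time of 72 h (on this read-out higher numbers stand for weaker inhibition and lower numbers for stronger inhibition), a limit.
Compound 2 `O=c1[nH]cnc2c1c(-c1cc3ccccc3o1)cn2[C@@H]1O[C@H](CO)[C@@H](O)[C@H]1O`: 62700 nM in this assay.
Compound 3 `Cc1nc(N)c2c(-c3cc4ccccc4o3)cn([C@@H]3O[C@H](CO)[C@@H](O)[C@H]3O)c2n1`: > 100000 nM, a limit.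

Among the compounds with values here, compound 2 gives the only number; the other two values sit at the limit of > 100000 nM in this assay, at which 2 of the 3 values shown sit. From compound 3 to compound 1 the change is phenyl in place of 1-benzofuran-2-yl on an aromatic carbon, and the resulting step is a step that the two limits leave unreadable from compound 3 to compound 1. How the core of compound 2 differs from that of compound 3 is not broken down here.

Compound 4 `O=c1[nH]cnc2c1c(-c1ccccc1)cn2[C@@H]1O[C@H](CO)[C@@H](O)[C@H]1O` is not yet measured. It differs from compound 2 by phenyl in place of 1-benzofuran-2-yl on an aromatic carbon, the same change at the same place as from compound 3 to compound 1. The step from compound 2 to compound 4 is expected to be a 1.4-fold higher number from compound 2 to compound 4 (0.16 log units; within the scatter). This expectation rests on compound 2 giving 62700 nM and on the step that the two limits leave unreadable from compound 3 to compound 1 being unreadable. Compound 4 is therefore estimated at 90000 nM, between 30000 nM and 300000 nM.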

Compound 4, half-maximal inhibitory concentration: > 100000 nM
Compound 4 gave a limit, no number (the forecaster's own chance of this, stated with the estimate: 50%); middle value at least 1.1-fold (0.04 log units) from the limit.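

In this assay, phenyl in place of 1-benzofuran-2-yl gives an at least 1.5-fold higher number from compound 2 to compound 4 (0.20 log units; that floor lies within the scatter), a floor set by a limit and not a measured size. On the core of compound 3 the same change cannot be read, so there is no second size to compare, and this pair neither confirms nor rules out that the step carries from one core to the other. Most of the set gives no number: the limit of > 100000 nM in this assay, at which 3 of the 4 values shown sit.

Still open, on these data alone, is how a group other than phenyl or 1-benzofuran-2-yl on that aromatic carbon, such as an amine, a carboxylic acid or a longer alkyl chain, would read in this assay.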